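This account rests on a few compounds, and the source may have more. Where it says the series, first, only, none or still open, it means among the compounds named here.

Measured so far in a functional assay on MIA PaCa-2 cells (Homo sapiens) for inhibition, read by MTT assay, with a stated time of 3 days; a higher number here means a weaker inhibitor, a lower number a stronger inhibitor:
- compound 1, `O=C([C@@H]1CCCN(S(=O)(=O)c2ccc(S(=O)(=O)C3CCC3)cc2)C1)N1CCC(F)(F)CC1`, gives only the assay limit > 3000 nM.
- compound 2, `O=C([C@@H]1CCCN(S(=O)(=O)c2ccc(S(=O)(=O)N3CC[C@@H](O)C3)cc2)C1)N1CCC(F)(F)CC1`, gives only the assay limit > 3000 nM.
- compound 3, `CCN(CC)S(=O)(=O)c1ccc(S(=O)(=O)N2CCC[C@@H](C(=O)N3CCC(COC)CC3)C2)cc1`, gives only the assay limit > 10000 nM.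

Compound 2 thus stands at the limit of > 3000 nM in this assay, at which 2 of the 3 values shown sit, and no number separates it from the other two compounds; compound 3 sits at the limit of > 10000 nM in this assay, at which 1 of the 3 values shown sits. Within the data shown here, the one step that touches compound 2, a step that the two limits leave unreadable from compound 1 to compound 2, is unreadable.

Compound 4, `CN(C)S(=O)(=O)c1ccc(S(=O)(=O)N2CCC[C@@H](C(=O)N3CCC(F)(F)CC3)C2)cc1`, differs from compound 2 by dimethylamino in place of 3-hydroxypyrrolidin-1-yl on a sulfonyl sulfur. Among the measured compounds shown here, no measured step bears on this change with a readable size, so no direction beyond the scatter can be expected in this assay. Compound 4 is therefore expected to give 6000 nM, within 1500 nM to 30000 nM, most likely again as a limit, meaning an estimated step that the limit leaves unreadable from compound 2 to compound 4.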

Compound 4, half-maximal inhibitory concentration: > 3000 nM
Compound 4 was reported as a limit; the forecaster's own chance of this, stated with the estimate: 80%; the middle value is on the limit's open side.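

In this assay, among these compounds, compound 4 gives > 3000 nM, which is a limit, so no step among compound 1, compound 2 and compound 4 can be read. On these data alone, whether any group on the sulfonyl sulfur shifts the read-out remains open.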